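Swapping methoxy for chloro on compound 1

A few compounds are considered here, and "the series" means these few. Any claim that something is new, unique, unknown or untested is made for them only; others in the source may bear on it.

In a functional assay on OVCAR-3 cells (Homo sapiens) for cytotoxicity, read by sulforhodamine B assay (on this read-out higher numbers stand for weaker inhibition of growth and lower numbers for stronger inhibition of growth), compound 1 (`COc1ccc(/C=N\NC(=S)NC(C)(C)CCC[C@](C)(O)[C@@H]2CC=C(C)CC2)cc1`) gives 6500 nM, and compound 2 (`CC1=CC[C@@H]([C@@](C)(O)CCCC(C)(C)NC(=S)N/N=C\c2ccccc2[N+](=O)[O-])CC1`) gives 7390 nM. The two are level, since a 1.1-fold higher number from compound 1 to compound 2 (0.06 log units; within the scatter) is a step that stays within the scatter. Together they hold the low end of the three numbers, while compound 3 (`CC1=CC[C@@H]([C@@](C)(O)CCCC(C)(C)NC(=S)N/N=C\c2ccccc2Cl)CC1`) stands apart at 42000 nM.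

Compound 4 (`CC1=CC[C@@H]([C@@](C)(O)CCCC(C)(C)NC(=S)N/N=C\c2ccc(Cl)cc2)CC1`) has not yet been measured. It keeps the core of compound 1 and differs in one group, with chloro in place of methoxy on an aromatic carbon, para to a large group: chloro in place of methoxy on an aromatic carbon. Among the measured compounds shown here, no measured pair makes exactly this change. The closest evidence is compound 3, which also carries chloro on its aromatic ring, though at a different place, and this gives a 6.5-fold higher number from compound 1 to compound 3 (0.81 log units; beyond the scatter). Chloro in place of nitro gives a 5.7-fold higher number from compound 2 to compound 3 (0.75 log units; beyond the scatter). Both steps are modest, lie beyond the scatter and run towards weaker inhibition of growth. Since the chloro of compound 4 sits elsewhere, only part of that shift is expected to carry over in this assay. The expected step is a 2.3-fold higher number from compound 1 to compound 4 (0.36 log units; beyond the scatter), a small rise in the number. For compound 4 the estimated value is 15000 nM, with an expected range from 5000 nM to 42000 nM.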

Compound 4, concentration for 50% growth inhibition: 6660 nM
For compound 4 the middle estimate is 2.3-fold (0.35 log units) above the measured one, and the stated range covers the measured number.
By their numbers in this assay, from the lowest: compounds 1, 4 and 2 (each within the scatter of the next); then compound 3.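

In this assay, chloro in place of methoxy, on an aromatic carbon para to a large group, leaves the read-out level (a 1.0-fold higher number from compound 1 to compound 4 (0.01 log units; within the scatter)), so 4-methoxyphenyl and 4-chlorophenyl cannot be told apart on this core. Among the compounds shown here, the pair of compound 3 and compound 4 is the first to keep the same group and change only its place, and it gives a clear step (a 6.3-fold lower number from compound 3 to compound 4 (0.80 log units; beyond the scatter)), which ties the weak result of compound 3 to 2-chlorophenyl and not to chloro as such, while 4-chlorophenyl and 2-nitrophenyl stay level (a 1.1-fold lower number from compound 2 to compound 4 (0.05 log units; within the scatter)). Nothing in hand explains why the place of the chloro counts for so much here.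

As far as these compounds go, it remains open whether an amine or a carboxylic acid in the same place, para to a large group, would also leave the read-out level with methoxy and chloro. From the compounds shown here alone, it is equally open whether 4-nitrophenyl would stay level with 2-nitrophenyl, or whether nitro would show the same dependence on place as chloro does.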